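Chlorine Moved from 4-Chlorophenyl to 2-Chlorophenyl

The source may hold more compounds than are shown below. What is called first, only, known or untested is meant among the compounds shown, and "the series" means these compounds.

Measured in an assay on liver for binding affinity to Alpha-1D adrenergic receptor (Homo sapiens), using microsomes; a lower number here means a stronger inhibitor, a higher number a weaker inhibitor:
Compound 1 `COC(=O)C1=C(C)NC(=O)N(C(=O)NCCCN2CCN(c3ccc(Cl)cc3)CC2)C1c1ccc(F)c(F)c1` — 52 nM
Compound 2 `CCOc1ccccc1N1CCN(CCCNC(=O)N2C(=O)NC(C)=C(C(=O)OC)C2c2ccc(F)c(F)c2)CC1` — 14 nM

Compound 1 has the highest of the two numbers; its nearest neighbour is compound 2, reached by a 3.7-fold lower number from compound 1 to compound 2 (0.57 log units; beyond the scatter). Compound 3 `COC(=O)C1=C(C)NC(=O)N(C(=O)NCCCN2CCN(c3ccccc3Cl)CC2)C1c1ccc(F)c(F)c1` keeps the same atoms as compound 1, joined differently: 2-chlorophenyl in place of 4-chlorophenyl on an amine nitrogen in a ring. Among the measured compounds shown here, the only measured step at this position, a 3.7-fold lower number from compound 1 to compound 2 (0.57 log units; beyond the scatter), moved the number modestly downward, so a modest lowering or no step beyond the scatter is expected here. Compound 3 is estimated at 30 nM, between 12 nM and 75 nM, which means an expected 1.7-fold lower number from compound 1 to compound 3 (0.24 log units; within the scatter).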

Compound 3, inhibition constant: 14 nM
For compound 3 the middle estimate is 2.1-fold (0.33 log units) above the measured one; measured number inside the range.
By their numbers in this assay, from the lowest: compounds 2 and 3 (each within the scatter of the next); then compound 1.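

In this assay, moving the chlorine alone gives a 3.7-fold lower number from compound 1 to compound 3 (0.57 log units; beyond the scatter) and shows that, with the atoms unchanged, its place on the phenyl ring affects the number, which the earlier step could not separate from a change of group. Chloro in place of ethoxy gives no change at the digits printed from compound 2 to compound 3 (within the scatter) and so shows no difference between these two groups on that aromatic carbon. No evidence available here explains either result. On these data alone, whether methoxy or fluoro on the same aromatic carbon would give a similar number remains open. So does the effect of a plain phenyl group.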